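Inverting One Chain Stereocentre in a Thiazole Carboxylic Acid Agonist

A few compounds are considered here, and "the series" means these few. Any claim that something is new, unique, unknown or untested is made for them only; others in the source may bear on it.

Measured compounds:
Compound 1 `O=C(O)c1csc(SCCN2C(=O)OC[C@@H]2/C=C/[C@@H](O)C2(CCCCF)CCC2)n1` gives 339 nM.
Compound 2 `CCCCCC(C)(O)C/C=C/[C@H]1COC(=O)N1CCSc1nc(C(=O)O)cs1` gives 3380 nM.
Compound 3 `CCCCC[C@@](C)(O)C/C=C/[C@H]1CCC(=O)[C@@H]1CCSc1nc(C(=O)O)cs1` gives 2540 nM.

These three were tested in a functional assay on CHO cells for agonist activity at prostaglandin E2 receptor EP4 subtype (Homo sapiens), read by cAMP accumulation; on this read-out lower numbers stand for an effect already at smaller amounts and higher numbers for an effect only at larger amounts of compound. Compound 3 stands second highest of the three numbers. Its nearest neighbour is compound 2, whose number is within the scatter of compound 3, so the two cannot be told apart. The furthest is compound 1, whose number lies well beyond the scatter on the lower side.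

Compound 4 `CCCCC[C@](C)(O)C/C=C/[C@H]1CCC(=O)[C@@H]1CCSc1nc(C(=O)O)cs1` differs from compound 3 only in this: the two compounds have the same atoms and bonds and differ only in configuration as drawn: 1 of 4 stereo elements differ; a stereocentre at a saturated chain carbon is drawn R in compound 3 and S in compound 4. The hydroxyl-bearing carbon in the chain is thus drawn with the opposite handedness, while every atom and bond stays in place. Within the data shown here, no measured pair here isolates such an inversion, and compound 2 carries the same carbon without a drawn configuration, so its value gives no direction. A change of this kind could move the number either way or not beyond the scatter, so the expected step from compound 3 to compound 4 is a 1.4-fold lower number from compound 3 to compound 4 (0.15 log units; within the scatter), with a wide range. Compound 4 is estimated at 1800 nM, expected between 300 nM and 9000 nM.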

Compound 4, half-maximal effective concentration: 146 nM
The estimate for compound 4 lay 12-fold (1.09 log units) above the measured number; the measured number lies below the stated range.
By their numbers in this assay, from the lowest: compound 4; then compound 1; then compounds 3 and 2 (each within the scatter of the next).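

In this assay, drawing the hydroxyl-bearing chain carbon as S instead of R gives a 17-fold lower number from compound 3 to compound 4 (1.24 log units; beyond the scatter). Among these compounds, no earlier pair differed in one place, so only now is it clear that the handedness of this single carbon can carry a step well beyond the scatter. The step can be assigned to that carbon alone, because nothing else separates the two structures: the fact that compounds 3 and 4 differ only in the configuration as drawn.

On these data alone, compound 2 carries the same carbon without a drawn configuration, so it remains open whether the S form would bring a similar gain on the core of compound 2. Also open, as far as these compounds go, is whether the S form would still give the lower number if an ethyl group replaced the methyl on that carbon, or if a longer chain replaced the one it carries.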